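The source may hold more compounds than are shown below. What is called first, only, known or untested is meant among the compounds shown, and "the series" means these compounds.

Measured so far in an ADME assay on BJ cells (Homo sapiens) for cytotoxicity, read by MTT assay, with a stated time of 72 h; a lower number here means a stronger inhibitor, a higher number a weaker inhibitor:
- compound 1 `COc1cccc(CNc2ncnc3c2ncn3C2CCCCO2)c1`: > 100000 nM
- compound 2 `COc1cccc(CNc2ncnc3c2ncn3C2CCCCO2)c1O`: > 100000 nM

Compound 2 stands at > 100000 nM, which is a limit of the assay and not a number. Compound 1, at > 100000 nM, is likewise recorded only as a limit. Among the compounds with values here, the series so far shows only (the limit of > 100000 nM in this assay, at which 2 of the 2 values shown sit). Within the data shown here, the single measured step is a step that the two limits leave unreadable from compound 1 to compound 2.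

Compound 3 `Oc1cccc(CNc2ncnc3c2ncn3C2CCCCO2)c1O` follows from compound 2 by hydrogen in place of methyl on an oxygen on an aromatic ring, methoxy to hydroxy. Among the measured compounds shown here, no measured step gives a size for this change, so no step beyond the scatter is expected in this assay, and a report at the limit is the likeliest outcome. The expected step is a number no higher from compound 2 to compound 3 (the limit leaves the size open). Compound 3 is estimated at 100000 nM, with an expected range from 40000 nM to 150000 nM.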

Compound 3, half-maximal inhibitory concentration: 63300 nM
Estimate against measurement, compound 3: 1.6-fold (0.20 log units) above, within the range that was stated.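

In this assay, within the data shown here, compound 3 is the first compound of the series to give a number and not a limit, which makes methoxy to hydroxy on this aromatic ring the first change with a readable floor: an at least 1.5-fold lower number from compound 2 to compound 3 (0.19 log units; that floor lies within the scatter). The full change from 3-methoxyphenyl to 2,3-dihydroxyphenyl gives the same kind of reading: an at least 1.5-fold lower number from compound 1 to compound 3 (0.19 log units; that floor lies within the scatter). Both floors lie within the scatter, so neither shows a change beyond it, and the series remains largely at its limit: the limit of > 100000 nM in this assay, at which 2 of the 3 values shown sit.

On these data alone, the true size of both steps stays open, as each starts from a limit. Also open, as far as these compounds go, is whether ethoxy, with a longer chain on that oxygen, or an amine on the aromatic ring in place of the hydroxy would give a number or stay at the limit.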